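This account rests on a few compounds, and the source may have more. Where it says the series, first, only, none or still open, it means among the compounds named here.

In a functional assay on THP-1 cells (Homo sapiens) for cytotoxicity, read by MTT assay, with a stated time of 24 h (on this read-out higher numbers stand for weaker inhibition and lower numbers for stronger inhibition), compound 1 (`COc1cc(/C=C2\CN(C)C/C(=C\c3ccccc3F)C2=O)cc(OC)c1`) gives 1170 nM, compound 2 (`COc1cc(/C=C2\CN(C)C/C(=C\c3ccccc3F)C2=O)cc(OC)c1OC`) gives 640 nM and compound 3 (`CN1C/C(=C\c2ccc(C#N)cc2)C(=O)/C(=C/c2ccccc2F)C1`) gives 810 nM. These three numbers lie within the usual scatter of one another, so compound 1 cannot be separated from the other two on this evidence.

The next compound to be tested is compound 4 (`COc1cc(/C=C2\CN(C)C/C(=C\c3ccc(Cl)c(Cl)c3)C2=O)cc(OC)c1`). It keeps the rest of compound 1 but carries 3,4-dichlorophenyl in place of 2-fluorophenyl on a double-bonded chain carbon bound to a double-bonded ring carbon.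

Among the measured compounds shown here, all three measured compounds carry the 2-fluorophenyl group, so no measurement yet shows what replacing it does. For the measured compounds named here, the only measured step, a 1.8-fold lower number from compound 1 to compound 2 (0.26 log units; within the scatter), is methoxy in place of hydrogen on an aromatic carbon. It lies elsewhere in the molecule and bears on this change only indirectly, as a sign that one edit to this series moved the number by no more than the scatter. With so little to go on, no shift beyond the scatter in either direction is expected in this assay.

The expected change is a 1.3-fold lower number from compound 1 to compound 4 (0.11 log units; within the scatter). For compound 4 the estimated value is 900 nM, with an expected range from 350 nM to 2200 nM.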

Compound 4, half-maximal inhibitory concentration: 3260 nM
Estimate against measurement, compound 4: 3.6-fold (0.56 log units) below; the measured number lies above the stated range.
By their numbers in this assay, from the lowest: compounds 2, 3 and 1 (each within the scatter of the next); then compound 4.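

Compound 1 and compound 4 differ only in the ring on a double-bonded chain carbon bound to a double-bonded ring carbon, and this change gives a 2.8-fold higher number from compound 1 to compound 4 (0.45 log units; beyond the scatter) in this assay. Among the compounds shown here, this is the first single change to move the number beyond the scatter, unlike the methoxy change, a 1.8-fold lower number from compound 1 to compound 2 (0.26 log units; within the scatter), so the aromatic group at this place can matter to the read-out. Here, 3,4-dichlorophenyl gives weaker inhibition than 2-fluorophenyl, but nothing available explains the difference, and this one step cannot separate losing the fluorine from gaining the two chlorines.

The compounds shown leave open whether a phenyl ring with a single chlorine, or plain phenyl with no halogen at all, would stay close to compound 1 or move towards compound 4. They also leave open whether 3,4-dichlorophenyl would raise the number to a similar degree on the shared core of compound 2, which carries the extra methoxy group.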